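The source may report more compounds than this note shows. Statements on the series, on what has been measured and on what is new or still open speak of the compounds shown alone.

Measured in a functional assay on HepG2 cells (Homo sapiens) for inhibition, read by MTT assay, with a stated time of 72 h, tested at 30 uM; on this read-out higher numbers stand for more inhibition of growth at the one concentration tested and lower numbers for less inhibition of growth:

- compound 1 `C=CCc1ccc(OCc2cn(-c3cccc([N+](=O)[O-])c3)nn2)c(O)c1`: 15.2%
- compound 2 `C=CCc1cc(O)c(O)c(CN2CCC(CCO)CC2)c1`: 2.5%
- compound 3 `C#CCOc1ccc(CC=C)cc1O`: 1.5%

Compound 1 stands highest of these three, and its distance to each of the other two lies beyond the usual scatter of repeated measurements. Compound 4 `C=CCc1ccc(OCc2cn(-c3cccc(C#N)c3)nn2)c(O)c1` keeps the core of compound 1 but has cyano in place of nitro on an aromatic carbon, meta to a large group: cyano in place of nitro on an aromatic carbon. Among the compounds with values here, none of the measured pairs shows this exchange, so the data offer no direct guide to its effect. The expected step of a number 2.2 percentage points lower from compound 1 to compound 4 (within the scatter) is small and stays within the scatter, with no firm direction. For compound 4 the estimated value in this assay is 13%, with an expected range from 3% to 28%.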

Compound 4, percent growth inhibition at one concentration: 2.3%
Estimate against measurement, compound 4: 10.7 percentage points above, and the stated range ends above it.
By their numbers in this assay, from the lowest: compounds 3, 4 and 2 (each within the scatter of the next); then compound 1.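

Putting cyano in place of nitro on this aromatic carbon brings a number 12.9 percentage points lower from compound 1 to compound 4 (beyond the scatter) in this assay, so the two groups are not interchangeable here. Within the data shown here, the earlier compounds held no exchange in one place, which makes this the first sign that the group at this position counts for the read-out. Nothing at hand gives a reason for this step.

From the compounds shown here alone, whether an amine or a carboxylic acid on this carbon would match compound 1 stays open. So does whether nitro elsewhere on the ring would do the same.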